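Adding a second chloro to the core of compound 2

A few compounds are considered here, and "the series" means these few. Any claim that something is new, unique, unknown or untested is made for them only; others in the source may bear on it.

Measured so far:
compound 1, `ClCc1ccccc1Cn1cnc2c(Cl)nc(Cl)nc21`: 3540 nM
compound 2, `ClCc1cccc(Cn2cnc3c(Cl)ncnc32)c1`: 11500 nM
compound 3, `ClCc1ccc(Cn2cnc3nc(Cl)nc(Cl)c32)cc1`: 44700 nM

These three compounds were tested in a functional assay on Hs-578T cells (Homo sapiens) for cytotoxicity, read by sulforhodamine B assay, with a stated time of 48 h; a higher number here means a weaker inhibitor of growth, a lower number a stronger inhibitor of growth. Compound 2 stands second highest of the three numbers: compound 1 gives the lower number, and the gap between them lies beyond the usual scatter; compound 3 gives the higher number, again beyond the scatter. Going by the values given here, compound 2 thus sits between its two neighbours, and no single-change step between any of the measured compounds exists, so nothing measured tells directly how one change alone shifts the result.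

Compound 4, `ClCc1cccc(Cn2cnc3c(Cl)nc(Cl)nc32)c1`, differs from compound 2 by one change: chloro in place of hydrogen on an aromatic carbon of the shared core. Among the compounds with values here, no such step has been measured. The size and direction of the expected change rest on nothing more than the spread of the measured values. A modest shift in this assay is expected, most likely toward a lower number, as a 1.4-fold lower number from compound 2 to compound 4 (0.16 log units; within the scatter) expresses. Compound 4 is therefore estimated at 8000 nM, with a plausible range from 2500 nM to 30000 nM.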

Compound 4, concentration for total growth inhibition: 4360 nM
Compound 4: the middle estimate sits 1.8-fold (0.26 log units) above what was measured; measured number inside the range.
By their numbers in this assay, from the lowest: compounds 1 and 4 (each within the scatter of the next); then compound 2; then compound 3.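

In this assay, going by these compounds alone, chloro in place of hydrogen on an aromatic carbon of the shared core, between two ring nitrogen atoms, gives a 2.6-fold lower number from compound 2 to compound 4 (0.42 log units; beyond the scatter) and so provides the first single-change step in this set. The step lies beyond the scatter, which shows that this position can affect the result: one added chlorine atom is enough to shift the compound toward stronger inhibition of growth. Nothing shown explains why the number falls.

Chloro is the only group seen here in place of that hydrogen, so it remains open whether an amine, a methoxy group or a longer chain at the same carbon would lower the number as well. From the compounds shown here alone, it also remains open whether the same change would shift the number on any compound other than compound 2.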